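The mirror image of compound 2

A few compounds are considered here, and "the series" means these few. Any claim that something is new, unique, unknown or untested is made for them only; others in the source may bear on it.

In a functional assay on KB cells (Homo sapiens) for cytotoxicity (a lower number here means a stronger inhibitor, a higher number a weaker inhibitor), compound 1 `CCCCCCCCCCCCCC[C@H]1N[C@H](CO)[C@H]1O` gives 6 ug/mL. Compound 2 `CCCCCCCCCCCCCC[C@@H]1N[C@H](CO)[C@H]1O` reaches only a limit, > 10 ug/mL. Compound 3 `CCCCCCCCCCCCCC[C@H]1N[C@@H](CO)[C@@H]1O` is related to compound 2 as follows: the two compounds have the same atoms and bonds and differ only in configuration as drawn: 3 of 3 stereo elements differ (all stereocentres are inverted: mirror images); a stereocentre at a saturated ring carbon is drawn S in compound 2 and R in compound 3; a stereocentre at a saturated ring carbon is drawn R in compound 2 and S in compound 3; a stereocentre at a saturated ring carbon is drawn S in compound 2 and R in compound 3. Going by the values given here, the only measured step, an at least 1.6-fold higher number from compound 1 to compound 2 (0.22 log units; that floor lies within the scatter), concerns configuration alone, as the fact that compounds 1 and 2 differ only in the configuration as drawn shows, and its floor stays within the scatter. For compound 3, a change no larger than the scatter is therefore expected. The expected step is an at least 1.1-fold lower number from compound 2 to compound 3 (0.04 log units; that floor lies within the scatter). Compound 3 is estimated at 9 ug/mL, with an expected range from 4 ug/mL to 20 ug/mL.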

Compound 3, half-maximal inhibitory concentration: 3.2 ug/mL
The estimate for compound 3 lay 2.8-fold (0.45 log units) above the measured number; the measured number lies below the stated range.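

In this assay, inverting every stereocentre at once brings an at least 3.1-fold lower number from compound 2 to compound 3 (0.49 log units; beyond the scatter), so a mirror pair separates beyond the scatter, which the earlier step did not show, and only configuration changes: the fact that compounds 2 and 3 differ only in the configuration as drawn. Compound 2 gives > 10 ug/mL, which is a limit, so that step is a floor. Inverting only two of the three stereocentres gives a 1.9-fold lower number from compound 1 to compound 3 (0.27 log units; within the scatter). From the compounds shown here alone, how large the gap within the mirror pair really is stays open. So does whether it persists with a shorter chain or with a carboxylic acid on the shared core.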